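The compounds below may be only part of what the source reports. "The series", "measured", "known", "first", "only" and "open" are said of these compounds alone.

Series notes. Compound 1 `CN(C)c1ccc2cc(-c3cc(Cl)cc(Cl)c3)c(N)nc2c1` and compound 2 `CN(C)c1ccc2cc(-c3cn(C)c4ccccc34)c(N)nc2c1` share the dimethylamino group but carry different cores; the difference between the two cores is not broken down here. In an ADME assay on microsomes from liver (Mus musculus) for metabolic stability, read by HPLC, with a stated time of 4 h (on this read-out lower numbers stand for a shorter-lived compound and higher numbers for a longer-lived compound), compound 1 gives 0.17 h, and in this assay compound 2 gives 0.26 h, two values within the usual scatter of each other. Compound 3 `CNc1ccc2cc(-c3cc(Cl)cc(Cl)c3)c(N)nc2c1` differs from compound 1 only by hydrogen in place of methyl on a nitrogen on an aromatic ring. In this assay compound 3 reaches the upper limit of the assay, > 4 h, so only a bound is known there; the read-out sits at the limit of > 4 h in this assay, at which 1 of the 3 values shown sits. The step of an at least 23-fold higher number from compound 1 to compound 3 (1.37 log units; beyond the scatter) is therefore a large one and beyond the scatter.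

Compound 4 `CNc1ccc2cc(-c3cn(C)c4ccccc34)c(N)nc2c1` stands to compound 2 as compound 3 stands to compound 1: the change is hydrogen in place of methyl on a nitrogen on an aromatic ring, the same change, at the same place, on the core of compound 2. Going by the values given here, only one measured instance of this change exists, on the core of compound 1, so the expectation for compound 4 rests on that single step. By analogy with the step from compound 1 to compound 3, a step of about a 12-fold higher number from compound 2 to compound 4 (1.06 log units; beyond the scatter) is expected from compound 2 to compound 4, with the real chance that only a limit is reported. Compound 4 is expected to give about 3 h in this assay, estimated between 0.6 h and 10 h.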

Compound 4, half-life: 1.3 h
Beside the measured number, compound 4's estimate is 2.3-fold (0.36 log units) above it, within the range that was stated.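

In this assay the change from dimethylamino to methylamino also lengthens the half-life on the second core, giving a 5.0-fold higher number from compound 2 to compound 4 (0.70 log units; beyond the scatter). The direction of the change thus carries over between these two cores, while its size does not carry over unchanged: the same change on two cores in this assay, an at least 23-fold higher number (1.37 log units; beyond the scatter) from compound 1 to compound 3 and a 5.0-fold higher number (0.70 log units; beyond the scatter) from compound 2 to compound 4, at least 4.7-fold (0.67 log units) apart, beyond the scatter of two such steps. Compound 3 stands at a limit of the assay, > 4 h, so the gap between the two steps is known only as a bound, and two cores show neither why the size differs nor how the change would behave on any further core.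

Open, on these data alone, is how a plain amine or an ethylamino group on this nitrogen would read in this assay on either core, and so whether the half-life follows the stepwise loss of methyl or depends on methylamino itself. Also open, as far as these compounds go, is how large the step on the core of compound 1 really is, and whether any other core would fall closer to the step on the core of compound 2.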